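A few compounds are considered here, and "the series" means these few. Any claim that something is new, unique, unknown or untested is made for them only; others in the source may bear on it.

Compound 1 `CN1CCN(CC(=O)Nc2ccc(-c3nc4cc(C(F)(F)F)ccc4n3C)cc2)CC1` gives 44000 nM in an ADME assay on MDBK cells (Bos taurus) for cytotoxicity, read by MTT assay, with a stated time of 96 h; a higher number here means that more compound is tolerated, a lower number that less compound is tolerated.
Compound 2 `Cn1c(-c2ccc(NC(=O)CN3CCCC3)cc2)nc2cc(C(F)(F)F)ccc21` gives 65000 nM in this assay.
Compound 3 `CCC(=O)Nc1ccc(-c2nc3cc(C(F)(F)F)ccc3[nH]2)cc1` reaches only a limit of the measurement, > 100000 nM, in this assay.

Compound 2 stands at the highest of the two plain numbers, with compound 1 nearest at a 1.5-fold higher number from compound 1 to compound 2 (0.17 log units; within the scatter), so the two cannot be told apart. The value of compound 3 is a limit of the measurement, not a number, and it is described by the limit of > 100000 nM in this assay, at which 1 of the 3 values shown sits.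

Compound 4 `CCN(CC)CC(=O)Nc1ccc(-c2nc3cc(C(F)(F)F)ccc3n2C)cc1` has not been measured. It differs from compound 2 in one place: diethylamino in place of pyrrolidin-1-yl on a saturated chain carbon bound to a carbonyl carbon. For the measured compounds named here, the only measured step that bears on this place is the one from compound 1 to compound 2, which swapped one small saturated amine for another and gave a 1.5-fold higher number from compound 1 to compound 2 (0.17 log units; within the scatter). Compound 4 again carries a small saturated amine at the same place, so the expectation is no step beyond the scatter: the estimated step from compound 2 to compound 4 is no change at the digits printed from compound 2 to compound 4 (within the scatter). Compound 4 is therefore expected to give about 65000 nM in this assay, with a likely range from 30000 nM to 130000 nM.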

Compound 4, half-maximal cytotoxic concentration: 57000 nM
For compound 4 the middle estimate is 1.1-fold (0.06 log units) above the measured one; low and high end bracket the measured number.
By their numbers in this assay, from the lowest: compounds 1, 4 and 2 (each within the scatter of the next). At a limit, above all of these: compound 3.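

Replacing pyrrolidin-1-yl with diethylamino on a saturated chain carbon bound to a carbonyl carbon opens the ring while keeping the same heavy-atom count, and this assay shows no readable change, with a 1.1-fold lower number from compound 2 to compound 4 (0.06 log units; within the scatter) for this swap. The earlier compounds shown here offered only a swap between two ring amines, whereas the open-chain amine now also sits within the scatter of the 4-methylpiperazin-1-yl compound, with a 1.3-fold higher number from compound 1 to compound 4 (0.11 log units; within the scatter) for that change. Among these three amines, then, a ring at this place makes no readable difference to how much compound the cells tolerate, but no measurement shown explains why the three values sit together.

On these data alone, it remains open whether a morpholine ring, a primary amine, a carboxylic acid or a longer chain between the carbonyl and the amine would also stay within the scatter. Compound 3 gives > 100000 nM in this assay, which is a limit of the measurement, and it differs from the other compounds in more than one place, so it does not show what removing the amine alone would do.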